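A few compounds are considered here, and "the series" means these few. Any claim that something is new, unique, unknown or untested is made for them only; others in the source may bear on it.

Compound 1 `Cc1[nH]c2ccccc2c1C1=CCN(Cc2ccc(OCC(=O)NO)cc2)CC1`: 697 nM
Compound 2 `O=C(COc1ccc(CN2CC=C(c3c[nH]c4ccc(F)cc34)CC2)c(F)c1)NO`: 3860 nM

Both values come from a functional assay on SW480 cells (Homo sapiens) for antiproliferative activity, with a stated time of 72 h; a higher number here means a weaker inhibitor, a lower number a stronger inhibitor. Compound 2 has the higher number of the two, 3860 nM, which makes it the weaker inhibitor, and its gap to compound 1 lies beyond the usual scatter. However, these two compounds differ in more than one place, so the gap cannot be assigned to any single group.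

Compound 3 `Cc1[nH]c2ccccc2c1C1=CCN(Cc2ccc(OCC(=O)NO)cc2F)CC1` has not yet been measured. It departs from compound 2 in one place, on a double-bonded ring carbon of a six-membered non-aromatic ring with 1 nitrogen, where 2-methyl-1H-indol-3-yl replaces 5-fluoro-1H-indol-3-yl (2-methyl-1H-indol-3-yl in place of 5-fluoro-1H-indol-3-yl on a double-bonded ring carbon). Going by the values given here, no measured pair shows this change alone, so any forecast is uncertain. Compound 1 carries the same entering group. Because compound 1 gives 697 nM with that group, a step to a lower number beyond the scatter is expected in this assay. The expected change is a 3.9-fold lower number from compound 2 to compound 3 (0.59 log units; beyond the scatter). For compound 3 the estimated value is 1000 nM, with an expected range of 350 nM to 3000 nM.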

Compound 3, half-maximal inhibitory concentration: 1600 nM
For compound 3 the middle estimate is 1.6-fold (0.20 log units) below the measured one; the measured number falls inside the stated range.
By their numbers in this assay, from the lowest: compound 1; then compound 3; then compound 2.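

In this assay, the exchange of 5-fluoro-1H-indol-3-yl for 2-methyl-1H-indol-3-yl on the double-bonded ring carbon now has a measured size of its own, a 2.4-fold lower number from compound 2 to compound 3 (0.38 log units; beyond the scatter), so the group at this position moves the number even with everything else held constant. Compound 3 also isolates a second single change, fluoro in place of hydrogen on an aromatic carbon, which gives a 2.3-fold higher number from compound 1 to compound 3 (0.36 log units; beyond the scatter), so neither change is silent and the two run in opposite directions: the 2-methyl group goes with the lower number, the added fluoro with the higher one. Nothing available here explains either step.

On these data alone, each step rests on a single pair of compounds, so it remains open whether the fluoro step would have the same size on a compound carrying 5-fluoro-1H-indol-3-yl, or the indole step on one without the fluoro. As far as these compounds go, it is also open how a chloro or methoxy group on that aromatic carbon, or an ethyl group in place of the 2-methyl, would compare.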